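The source may hold more compounds than are shown below. What is called first, only, known or untested is meant among the compounds shown, and "the series" means these compounds.

Measured so far in a physicochemical assay for solubility, with a stated time of 18 h, at pH 7.4; on this read-out lower numbers stand for lower solubility and higher numbers for higher solubility:
- compound 1 `O=[N+]([O-])c1ccc(C2=NOC(c3ccc(N4CCCCC4)cc3)C2)o1`: 1.1 ug/mL
- compound 2 `O=C1COCCN1c1ccc(C2CC(c3ccc([N+](=O)[O-])o3)=NO2)cc1F`: 12.6 ug/mL

Going by the values given here, with only two numbers in hand, compound 2 holds the higher one at 12.6 ug/mL, and its gap to compound 1 lies beyond the scatter. These two compounds differ in more than one place, so their gap does not show what any single change does.

The next compound to be measured is compound 3 `CN1CCN(c2ccc(C3CC(c4ccc([N+](=O)[O-])o4)=NO3)cc2F)C(=O)C1`. It differs from compound 2 in one group: 4-methyl-2-oxopiperazin-1-yl in place of 3-oxomorpholin-4-yl on an aromatic carbon. In words, 4-methyl-2-oxopiperazin-1-yl stands in place of 3-oxomorpholin-4-yl, on an aromatic carbon, ortho to a fluoro group. Each of the two groups is one six-membered non-aromatic ring with 2 hetero atoms, and the rest of the molecule stays the same.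

Among the compounds with values here, no measured pair shows this swap on its own, so any expectation here is loose. A small upward move in this assay is expected, probably not beyond the scatter: the estimated change is a 1.6-fold higher number from compound 2 to compound 3 (0.20 log units; within the scatter). For compound 3 the expected value is 20 ug/mL, with an estimated range from 7 ug/mL to 55 ug/mL.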

Compound 3, solubility: 29.2 ug/mL
The estimate for compound 3 lay 1.5-fold (0.16 log units) below the measured number; low and high end bracket the measured number.
By their numbers in this assay, from the lowest: compound 1; then compound 2; then compound 3.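

Going by these compounds alone, compound 2 and compound 3 give the first comparison in this assay that differs in one place: replacing 3-oxomorpholin-4-yl with 4-methyl-2-oxopiperazin-1-yl on an aromatic carbon, ortho to a fluoro group, gives a 2.3-fold higher number from compound 2 to compound 3 (0.37 log units; beyond the scatter). Each group is one six-membered non-aromatic ring with 2 hetero atoms, and the counts of hydrogen-bond donors and acceptors stay the same, so even a swap between such closely matched rings can move this read-out at this position. No measurement on hand gives a reason for the step.

The compounds shown leave open how much of the step belongs to the methyl group and how much to the change of ring atoms, and whether the same swap would give a similar step on a core without the fluoro group. They also leave open how a quite different group at this position, such as a dimethylamino group or a carboxylic acid, would compare with these two rings.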